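Swapping One Benzyl Ring in a Series With Low Inhibition Numbers

The compounds below may be only part of what the source reports. "The series", "measured", "known", "first", "only" and "open" are said of these compounds alone.

Compound 1 `COc1ccc(C2N=C(SCc3ccc(Cl)cc3)NC(C)=C2C(=O)Nc2ccc(F)cc2)cc1OC`: 3.1%
Compound 2 `CC1=C(C(=O)Nc2ccc(Br)cc2)C(c2ccc(Cl)cc2Cl)N=C(SCc2ccccc2)N1`: 1.5%
Compound 3 `CC1=C(C(=O)Nc2ccc([N+](=O)[O-])cc2)C(c2ccc(Br)cc2)N=C(SCc2ccccc2Cl)N1`: 1.5%

All three measured compounds were tested in a functional assay on the whole organism (artery, strain albino) with Rattus norvegicus as the target, with a stated time of 15 min, at a dose of 10 mg/kg by the oral route; a lower number here means less inhibition, a higher number more inhibition at the dose given (going by the name of the read-out). Compound 3 stands level with compound 2 at the digits printed, and the two together are the lowest of the three numbers; compound 1 lies a little higher, but that gap sits within the scatter, so nothing separates the three in practice.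

The unmeasured compound 4 `CC1=C(C(=O)Nc2ccc([N+](=O)[O-])cc2)C(c2ccc(Br)cc2)N=C(SCc2ccc(F)cc2)N1` is compound 3 with one ring changed: 4-fluorophenyl in place of 2-chlorophenyl on a saturated chain carbon bound to a sulfur. Among the compounds with values here, no measured pair shows this change, so its effect is unknown. Within the data shown here, with every value so far near zero, compound 4 is expected to follow suit, a step of a number 1 percentage points higher from compound 3 to compound 4 (within the scatter), none beyond the scatter. The estimate for compound 4 in this assay is 2.5%, ranging from 0% to 12%.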

Compound 4, a percentage reported as inhibition, in the whole organism at one dose (the size of the read-out at that dose, not a potency): 2.6%
Estimate against measurement, compound 4: 0.1 percentage points below; measured number inside the range.
By their numbers in this assay, from the lowest: compounds 2, 3, 4 and 1 (each within the scatter of the next).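

In this assay, within the data shown here, the swap of 2-chlorophenyl for 4-fluorophenyl on a saturated chain carbon bound to a sulfur gives a number 1.1 percentage points higher from compound 3 to compound 4 (within the scatter) and is the first direct reading of a change at this position. Exchanging one halogen-bearing ring for the other therefore does not lift this number clear of the scatter. Nothing measured here bears on why the number holds.

Still open, going by these compounds, is whether a different group at this position, such as an amine, a carboxylic acid or a longer chain in place of the benzyl ring, would produce a step beyond the scatter.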